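Benzyloxy variation on the shared core

The source may hold more compounds than are shown below. What is called first, only, known or untested is meant among the compounds shown, and "the series" means these compounds.

Within the data shown here, compound 1 `Cc1cccc(COc2ccc(-c3cc(CN4CCN(Cc5ccc(C(F)(F)F)cc5)CC4)no3)cc2)c1` stands with the highest number of the two measured so far; in a functional assay on Huh-7 cells (Homo sapiens) for antiproliferative activity, read by sulforhodamine B assay, with a stated time of 72 h (a higher number here means a weaker inhibitor, a lower number a stronger inhibitor), compound 1 gives 5000 nM. Compound 2 `COc1ccccc1COc1ccc(-c2cc(CN3CCN(Cc4ccc(C(F)(F)F)cc4)CC3)no2)cc1` gives 900 nM in this assay. Among the measured compounds shown here, the step of a 5.6-fold lower number from compound 1 to compound 2 (0.74 log units; beyond the scatter) is the only measured change at this position. Compound 3 `COc1ccc(COc2ccc(-c3cc(CN4CCN(Cc5ccc(C(F)(F)F)cc5)CC4)no3)cc2)cc1` is not yet measured; it differs from compound 1 in 4-methoxyphenyl in place of 3-methylphenyl on a saturated chain carbon bound to an oxygen on an aromatic ring. The change resembles the step to compound 2 in that 3-methylphenyl leaves and a methoxyphenyl enters, here 4-methoxyphenyl rather than 2-methoxyphenyl, so that step bears on it only in part. For the measured compounds named here, a lowering of the number beyond the scatter is expected, though a step smaller than the one to compound 2 is as likely as a match. The expected step is a 3.1-fold lower number from compound 1 to compound 3 (0.49 log units; beyond the scatter). Compound 3 is estimated at 1600 nM, between 500 nM and 5000 nM.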

Compound 3, half-maximal inhibitory concentration: 3200 nM
Compound 3: the middle estimate sits 2.0-fold (0.30 log units) below what was measured; the range from low to high includes it.
By their numbers in this assay, from the lowest: compound 2; then compounds 3 and 1 (each within the scatter of the next).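

In this assay, a methoxy group on the phenyl ring does not by itself lower the number: 4-methoxyphenyl in place of 3-methylphenyl gives a 1.6-fold lower number from compound 1 to compound 3 (0.19 log units; within the scatter), so these two groups cannot be told apart here. With the methoxy group kept, 4-methoxyphenyl in place of 2-methoxyphenyl gives a 3.6-fold higher number from compound 2 to compound 3 (0.55 log units; beyond the scatter), so among these three compounds the lower number is seen only with 2-methoxyphenyl, and where the methoxy group sits on the phenyl ring matters at this position. No evidence is available to explain this difference.

Still open, as far as these compounds go, is whether the lower number depends on the methoxy group itself, which 2-methylphenyl or 2-ethoxyphenyl would test. From the compounds shown here alone, the standing of 3-methoxyphenyl, which would complete the methoxy set, also remains open.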